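The source may report more compounds than this note shows. Statements on the series, on what has been measured and on what is new or still open speak of the compounds shown alone.

Compound 1, with the structure `c1cncc(-c2ccccc2OCC2=NCCN2)c1`, carries a pyridin-3-yl group on its aromatic core. In a functional assay for activation of Alpha-1D adrenergic receptor (Homo sapiens), read by calcium flux (on this read-out higher numbers stand for an effect only at larger amounts of compound and lower numbers for an effect already at smaller amounts), compound 1 gives 158 nM. Compound 2, with the structure `c1ccc(-c2ccncc2)c(OCC2=NCCN2)c1`, differs from it only by bearing pyridin-4-yl in place of pyridin-3-yl on an aromatic carbon. For compound 2 this assay reports only a limit, < 100000 nM, not a number. The step that the limit leaves unreadable from compound 1 to compound 2 therefore cannot be read in size, and the only point of reference is the limit of < 100000 nM in this assay, at which 1 of the 2 values shown sits.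

Compound 3, with the structure `c1cnc(-c2ccccc2OCC2=NCCN2)nc1`, has not yet been measured. It differs from compound 2 by pyrimidin-2-yl in place of pyridin-4-yl on an aromatic carbon. Among the measured steps, only the one from compound 1 to compound 2 touches this region of the molecule, and its size is not readable, so no direction or size for the new step can be taken from the data. What remains is that compound 2 stands at a limit in this assay, while compound 1 shows a clear number. The step from compound 2 to compound 3 is expected to be roughly a step that the limit leaves unreadable from compound 2 to compound 3, with wide uncertainty. For compound 3 a value of 2000 nM is estimated, within a range from 150 nM to 30000 nM.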

Compound 3, half-maximal effective concentration: < 100000 nM
Compound 3: only a limit was reported; the forecaster's own chance of this, stated with the estimate: 30%; the middle value is on the limit's open side.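

Compound 3 gives only a limit in this assay, < 100000 nM, and not a number, so the steps to compound 3 from compound 1 and from compound 2 cannot be read in size: the limit of < 100000 nM in this assay, at which 2 of the 3 values shown sit.

The compounds shown leave open how pyridin-4-yl and pyrimidin-2-yl compare with each other, and with pyridin-3-yl, in this assay.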